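Amino in place of hydroxy on compound 2

The compounds below may be only part of what the source reports. "The series", "measured", "known", "first", "only" and "open" are said of these compounds alone.

In a functional assay on T47D cells (Homo sapiens) for cytotoxicity, read by trypan blue exclusion, with a stated time of 96 h (a lower number here means a stronger inhibitor of growth, a higher number a weaker inhibitor of growth), compound 1 (`COc1ccc(NS(=O)(=O)/C=C/c2c(OC)cc(OC)cc2OC)cc1`) gives 100 nM and compound 2 (`COc1cc(OC)c(/C=C/S(=O)(=O)Nc2ccc(OC)c(O)c2)c(OC)c1`) gives 25 nM, the lower of the two numbers. Compound 3 (`COc1cc(OC)c(/C=C/S(=O)(=O)Nc2ccc(OC)c(N)c2)c(OC)c1`) has amino in place of hydroxy on an aromatic carbon. Among the measured compounds shown here, one measured step bears on this place, the modest 4.0-fold lower number from compound 1 to compound 2 (0.60 log units; beyond the scatter), where hydroxy replaces hydrogen. For the measured compounds named here, no measured compound carries amino there, so the evidence is thin, and no step beyond the scatter is expected in either direction in this assay. The estimated step is a 1.2-fold higher number from compound 2 to compound 3 (0.08 log units; within the scatter). For compound 3 the expected value is 30 nM, within an estimated range of 8 nM to 100 nM.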

Compound 3, concentration for 50% growth inhibition: 8 nM
For compound 3 the middle estimate is 3.8-fold (0.57 log units) above the measured one; low and high end bracket the measured number.
By their numbers in this assay, from the lowest: compound 3; then compound 2; then compound 1.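

In this assay, the place ortho to a methoxy group responds to which group sits there, not merely to whether one does: amino in place of hydroxy gives a 3.1-fold lower number from compound 2 to compound 3 (0.49 log units; beyond the scatter). Set against the hydrogen of the parent, amino gives a 13-fold lower number from compound 1 to compound 3 (1.10 log units; beyond the scatter), so hydroxy is not the only group here that lowers the number. Nothing at hand explains the difference between amino and hydroxy. The compounds shown leave open whether a methylamino, dimethylamino or acetamido group at this place would keep the lower number.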